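Spiro series: aryl swap on the saturated ring carbon

This account rests on a few compounds, and the source may have more. Where it says the series, first, only, none or still open, it means among the compounds named here.

Three compounds of the series have numbers in a functional assay on MCF7 cells (Homo sapiens) for antiproliferative activity, read by MTT assay, with a stated time of 48 h; on this read-out higher numbers stand for weaker inhibition and lower numbers for stronger inhibition:

compound 1, `O=C1Nc2ccccc2[C@]12N[C@H](c1ccccc1)[C@H](c1ccccc1)[C@@]21CCc2c([nH]c3ccc(Cl)cc23)C1=O`, gives 18000 nM
compound 2, `O=C1Nc2ccccc2[C@]12N[C@H](c1ccccc1)[C@H](c1cccs1)[C@@]21CCc2c([nH]c3ccc(Cl)cc23)C1=O`, gives 13000 nM
compound 3, `O=C1Nc2ccccc2[C@]12N[C@H](c1ccccc1)[C@H](c1cccs1)[C@@]21CCc2c([nH]c3ccccc23)C1=O`, gives 15000 nM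

Compound 2 holds the lowest of the three numbers, but its distances to the other two are small: the step of a 1.4-fold lower number from compound 1 to compound 2 (0.14 log units; within the scatter) and the step of a 1.2-fold higher number from compound 2 to compound 3 (0.06 log units; within the scatter) both sit within the scatter, so the three compounds cannot be ordered against each other on these data.

Compound 4, `COc1ccc([C@H]2[C@@H](c3ccccc3)N[C@@]3(C(=O)Nc4ccccc43)[C@]23CCc2c([nH]c4ccc(Cl)cc24)C3=O)cc1`, is the next compound for this assay. It differs from compound 2 by 4-methoxyphenyl in place of thiophen-2-yl on a saturated ring carbon.

Among the compounds with values here, the measured step that bears on this position is the one from compound 1 to compound 2, where thiophen-2-yl took the place of phenyl; that step stayed within the scatter. The change from compound 2 to compound 4 brings an aromatic group back onto the same carbon, now carrying a methoxy substituent. The step from compound 2 to compound 3 concerns a different position and adds nothing here. Within the data shown here, with only one step at this position, and that one within the scatter, no movement beyond the scatter is expected in this assay; the step of a 1.2-fold higher number from compound 2 to compound 4 (0.06 log units; within the scatter) is the estimate. Compound 4 is therefore expected to give about 15000 nM in this assay, with a range from 7000 nM to 32000 nM.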

Compound 4, half-maximal inhibitory concentration: 19000 nM
Compound 4: the middle estimate sits 1.3-fold (0.10 log units) below what was measured, and the stated range covers the measured number.
By their numbers in this assay, from the lowest: compounds 2, 3, 1 and 4 (each within the scatter of the next).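

In this assay, the saturated ring carbon has now held phenyl, thiophen-2-yl and 4-methoxyphenyl on the same chloro-bearing core, and the step of a 1.5-fold higher number from compound 2 to compound 4 (0.16 log units; within the scatter) stays within the scatter, as does the step of a 1.1-fold higher number from compound 1 to compound 4 (0.02 log units; within the scatter). Within the data shown here, the second of these is the first reading of a substituent on the aryl group at this position, and the first shows that going from the 5 heavy atoms of thiophen-2-yl to the 8 of 4-methoxyphenyl, with one hydrogen-bond acceptor on each side, moves the number no further than repeat measurements would. Across these aromatic groups the position therefore shows no readable difference in this antiproliferative read-out, and nothing available alongside these numbers speaks to an explanation for that.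

From the compounds shown here alone, it remains open whether a group of another kind on this carbon or on its aryl ring, such as a carboxylic acid, a dimethylamino group or a saturated cyclohexyl ring, would move the number beyond the scatter. Also open, going by these compounds, is whether 4-methoxyphenyl behaves the same way on the core with hydrogen in place of chloro, as in compound 3.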